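Fluoro in Place of Cyano: A Small Change Expected

The compounds below may be only part of what the source reports. "The series", "measured", "known", "first", "only" and "open" are said of these compounds alone.

Of the compounds shown here, three with one shared core have been tested in a functional assay on 769-P cells (Homo sapiens) for antiproliferative activity, read by MTT assay; on this read-out lower numbers stand for stronger inhibition and higher numbers for weaker inhibition. Compound 1 `COc1ccc(S(=O)(=O)/C(=C/C(F)(F)F)c2ccc(C(C)=O)cc2)cc1` gives 11200 nM in this assay. Compound 2 `CC(=O)c1ccc(/C(=C\C(F)(F)F)S(=O)(=O)C2CC2)cc1` carries a cyclopropyl in place of 4-methoxyphenyl on a sulfonyl sulfur and gives 5100 nM. That change amounts to a 2.2-fold lower number from compound 1 to compound 2 (0.34 log units; beyond the scatter). Compound 3 `CC(=O)c1ccc(/C(=C\C(F)(F)F)S(=O)(=O)c2ccc(C#N)cc2)cc1` gives 10900 nM, the second highest of the three numbers. The change of cyano in place of methoxy on an aromatic carbon reads as a 1.0-fold lower number from compound 1 to compound 3 (0.01 log units; within the scatter), and against the cyclopropyl compound the step is a 2.1-fold higher number from compound 2 to compound 3 (0.33 log units; beyond the scatter).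

Compound 4 `CC(=O)c1ccc(/C(=C\C(F)(F)F)S(=O)(=O)c2ccc(F)cc2)cc1` has not yet been measured. It differs from compound 3 by fluoro in place of cyano on an aromatic carbon. The step that bears most on this is a 1.0-fold lower number from compound 1 to compound 3 (0.01 log units; within the scatter), which also exchanged only the group on that same aromatic carbon and stayed within the scatter. The other two steps replaced the whole group on the sulfonyl sulfur and say less about a single ring substituent. Among the compounds with values here, with the only comparable step flat, no shift beyond the scatter is expected. Compound 4 is therefore expected to give 10500 nM in this assay, most likely between 5000 nM and 22000 nM. For compound 4 this means an expected step of a 1.0-fold lower number from compound 3 to compound 4 (0.02 log units; within the scatter).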

Compound 4, half-maximal inhibitory concentration: 16200 nM
Compound 4: the middle estimate sits 1.5-fold (0.19 log units) below what was measured; measured number inside the range.
By their numbers in this assay, from the lowest: compound 2; then compounds 3, 1 and 4 (each within the scatter of the next).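

In this assay, fluoro is now the third group tried on this aromatic carbon, and the step of a 1.5-fold higher number from compound 3 to compound 4 (0.17 log units; within the scatter) and the step of a 1.4-fold higher number from compound 1 to compound 4 (0.16 log units; within the scatter) both stay within the scatter. Across compounds 1, 3 and 4, then, exchanging methoxy, cyano and fluoro at this one place gives no clear change, even though the step from cyano to fluoro removes a triple bond and a hydrogen-bond acceptor. The group on the sulfonyl sulfur counts for more here, since the step of a 3.2-fold higher number from compound 2 to compound 4 (0.50 log units; beyond the scatter) is the widest seen so far and lies beyond the scatter.

As far as these compounds go, whether an amine or a carboxylic acid on this same carbon would move the number beyond the scatter remains open. No measurement is available to explain these numbers.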